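The source may report more compounds than this note shows. Statements on the series, on what has been measured and on what is new or still open speak of the compounds shown alone.

Working notes on the series. Of the compounds shown here, three sharing one core have been measured in a functional assay on MCF7 cells (Homo sapiens) for cytotoxicity, read by MTT assay; on this read-out lower numbers stand for stronger inhibition and higher numbers for weaker inhibition. Compound 1 `COc1ccc(/C=C2\CCC/C(=C\c3ccccc3[N+](=O)[O-])C2=O)cc1` gives 11.2 ug/mL. Compound 2 `COc1cccc(/C=C2\CCC/C(=C\c3ccccc3[N+](=O)[O-])C2=O)c1` gives 5.62 ug/mL; the step of a 2.0-fold lower number from compound 1 to compound 2 (0.30 log units; within the scatter) stays inside the scatter. Compound 3 `COc1cc(/C=C2\CCC/C(=C\c3ccccc3[N+](=O)[O-])C2=O)cc(Br)c1OC` gives 3.35 ug/mL. Set against the other two numbers, compound 3 and compound 2 lie within the scatter of each other, so no order between them is claimed, while the gap between compound 3 and compound 1 lies beyond the scatter.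

The next compound is compound 4 `CCCOc1c(Br)cc(/C=C2\CCC/C(=C\c3ccccc3[N+](=O)[O-])C2=O)cc1OC`. Against compound 3 the change is ethyl in place of hydrogen on a saturated chain carbon bound to an oxygen on an aromatic ring. Going by the values given here, no measured step in this set touches the same change: the only step on record, the shift of the methoxy group between compound 1 and compound 2, alters a different part of the molecule and was itself within the scatter. There is thus no measured basis for expecting movement in this assay from extending the alkoxy chain in either direction, and the working expectation is a step within the scatter, a 1.0-fold higher number from compound 3 to compound 4 (0.02 log units; within the scatter).

On that basis compound 4 is estimated at 3.5 ug/mL in this assay, with a range from 1.6 ug/mL to 7.5 ug/mL.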

Compound 4, half-maximal inhibitory concentration: 4.14 ug/mL
The estimate for compound 4 lay 1.2-fold (0.07 log units) below the measured number; measured number inside the range.
By their numbers in this assay, from the lowest: compounds 3, 4, 2 and 1 (each within the scatter of the next, the first and the last beyond it).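

Methoxy to propoxy on the saturated chain carbon bound to an oxygen on an aromatic ring gives the first reading of this alkoxy chain in this assay: a 1.2-fold higher number from compound 3 to compound 4 (0.09 log units; within the scatter). Where the one earlier step concerned the place of a methoxy group, this one shows that ethyl in place of hydrogen at this position leaves the number within the scatter, so no order is claimed between the methoxy and propoxy compounds, and the pair gives no sign that this position requires the shorter chain. No accompanying evidence bears on why the number stays within the scatter across this change.

Going by these compounds, this rests on a single pair carrying the bromine of compound 3 and compound 4, so it remains open whether propoxy would read the same on a compound without that bromine, such as compound 2 or compound 1. On these data alone, it is also open whether the number would stay within the scatter with a longer chain such as octyloxy, or with an amine or a carboxylic acid at the end of the chain.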